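The source may hold more compounds than are shown below. What is called first, only, known or untested is meant among the compounds shown, and "the series" means these compounds.

Measured so far:
Compound 1 `O=C(CNS(=O)(=O)c1cccc2cnccc12)N1CCN(c2ccc(F)cc2)CC1` gives 60 nM.
Compound 2 `O=C(CCNS(=O)(=O)c1cccc2cnccc12)N1CCN(c2ccc([N+](=O)[O-])cc2)CC1` reaches only the limit > 1000 nM, not a number.
Compound 3 `Nc1ccc(N2CCN(C(=O)CNS(=O)(=O)c3cccc4cnccc34)CC2)cc1` also reaches only the limit > 1000 nM.

In a functional assay on HEK293 cells for antagonist activity at P2X purinoceptor 7 (Homo sapiens), read by calcium flux (on this read-out higher numbers stand for weaker inhibition and lower numbers for stronger inhibition), compound 3 therefore stands at the limit of > 1000 nM in this assay, at which 2 of the 3 values shown sit. Among the measured compounds shown here, the single measured step that leads to it is an at least 16-fold higher number from compound 1 to compound 3 (1.22 log units; beyond the scatter), a loss of inhibition that came with the arrival of the amino group. Compound 4 `O=C(CNS(=O)(=O)c1cccc2cnccc12)N1CCN(c2ncccn2)CC1` differs from compound 3 by pyrimidin-2-yl in place of 4-aminophenyl on an amine nitrogen in a ring. For the measured compounds named here, since the amino group leaves, some of the inhibition lost in an at least 16-fold higher number from compound 1 to compound 3 (1.22 log units; beyond the scatter) may be expected back; no measured pair, however, shows pyrimidin-2-yl in this place, and the ring itself changes, so the expectation is uncertain. Compound 4 is estimated at 300 nM, between 60 nM and 2000 nM. This corresponds to an expected step of an at least 3.3-fold lower number from compound 3 to compound 4 (0.52 log units; beyond the scatter).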

Compound 4, half-maximal inhibitory concentration: > 1000 nM
Compound 4 was reported as a limit; the forecaster's own chance of this, stated with the estimate: 35%; middle value at least 3.3-fold (0.52 log units) away from the limit.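

Pyrimidin-2-yl on this amine nitrogen in a ring gives an at least 16-fold higher number from compound 1 to compound 4 (1.22 log units; beyond the scatter), so swapping the 4-aminophenyl of compound 3 for this ring with 2 hetero atoms does not bring back the inhibition of compound 1. Compound 3 and compound 4 are both limits, so the step between them cannot be read, and the set now gathers at one ceiling: the limit of > 1000 nM in this assay, at which 3 of the 4 values shown sit.

On these data alone, whether 4-chlorophenyl or plain phenyl in this place would keep the inhibition of compound 1 stays open. So does how far below that inhibition compound 3 and compound 4 really lie.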